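Bromo to methyl swap in the series

The source may report more compounds than this note shows. Statements on the series, on what has been measured and on what is new or still open speak of the compounds shown alone.

- compound 1 `C=C(Br)C(=O)Nc1ccc(/C=C/C(=O)c2ccc(C)cc2)cc1` gives 1800 nM
- compound 2 `Nc1ccc(/C=C/C(=O)c2ccc(Br)cc2)cc1` gives 14000 nM

In an ADME assay on CCRF-CEM cells (Homo sapiens) for antiproliferative activity, with a stated time of 48 h (on this read-out higher numbers stand for weaker inhibition and lower numbers for stronger inhibition), compound 2 at 14000 nM holds the higher of the two numbers. Compound 1 at 1800 nM lies lower, and this gap is beyond the usual scatter.

Next comes compound 3 `Cc1ccc(C(=O)/C=C/c2ccc(N)cc2)cc1`, which has methyl in place of bromo on an aromatic carbon, para to a large group (methyl in place of bromo on an aromatic carbon). Among the compounds with values here, no measured pair shows this change alone, so the data offer no direct guide. Only a small move toward a lower number is expected in this assay, not beyond the scatter. The expected step of a 1.4-fold lower number from compound 2 to compound 3 (0.15 log units; within the scatter) is an estimate without measured support. For compound 3 the estimated value is 10000 nM with an expected range from 4000 nM to 30000 nM on current evidence.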

Compound 3, half-maximal inhibitory concentration: 31000 nM
For compound 3 the middle estimate is 3.1-fold (0.49 log units) below the measured one; measured number above the stated range.
By their numbers in this assay, from the lowest: compound 1; then compound 2; then compound 3.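

On the aromatic carbon para to a large group, methyl in place of bromo gives a 2.2-fold higher number from compound 2 to compound 3 (0.35 log units; beyond the scatter) in this assay, so the swap is not neutral at this position and bromo goes with the lower number in this pair. On the nitrogen on the aromatic ring, hydrogen in place of (1-bromoethenyl)carbonyl gives a 17-fold higher number from compound 1 to compound 3 (1.24 log units; beyond the scatter), a larger step than the one at the aromatic carbon. No measurement at hand bears on why either step arises.

From the compounds shown here alone, whether bromo still goes with the lower number when the nitrogen carries (1-bromoethenyl)carbonyl stays open. Also open, going by these compounds, is where chloro, methoxy or a carboxylic acid on the aromatic carbon would fall relative to bromo and methyl, and whether a plain acetyl on the nitrogen would give a number closer to that of compound 1 or compound 3.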